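This account rests on a few compounds, and the source may have more. Where it says the series, first, only, none or still open, it means among the compounds named here.

So far, two compounds built on a shared core have been tested in a functional assay on OS-RC-2 cells (Homo sapiens) for antiproliferative activity, read by MTT assay, with a stated time of 72 h; a lower number here means a stronger inhibitor, a higher number a weaker inhibitor. Compound 1 `O=C1C=C(N2CCN(c3ccccc3Cl)CC2)C(=O)c2ccccc21` gives 8900 nM, while compound 2 `O=C1C=C(N2CCN(c3ccccc3Cl)CC2)C(=O)c2c(O)cccc21` gives 2500 nM. Compound 2 therefore holds the lower of the two numbers and is the stronger inhibitor of the pair.

The next compound to be tested is compound 3 `Cc1ccccc1N1CCN(C2=CC(=O)c3cccc(O)c3C2=O)CC1`, which differs from compound 2 in one place: methyl in place of chloro on an aromatic carbon. This is methyl in place of chloro on an aromatic carbon, turning 2-chlorophenyl into 2-methylphenyl.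

For the measured compounds named here, only one measured step is available as a guide, a 3.6-fold lower number from compound 1 to compound 2 (0.55 log units; beyond the scatter), and it comes from a different change, hydroxy in place of hydrogen on an aromatic carbon. Going by the values given here, no measured pair tests the swap from chloro to methyl, so the data give no direction for it. That single modest step shows only how far one small change has moved the number here, and no step beyond the scatter is expected this time.

The estimated change is a 1.1-fold higher number from compound 2 to compound 3 (0.05 log units; within the scatter). Compound 3 is expected to give about 2800 nM, with an estimated range of 1200 nM to 6500 nM.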

Compound 3, half-maximal inhibitory concentration: 4400 nM
Beside the measured number, compound 3's estimate is 1.6-fold (0.20 log units) below it, within the range that was stated.
By their numbers in this assay, from the lowest: compounds 2 and 3 (each within the scatter of the next); then compound 1.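

In this assay there is a 1.8-fold higher number from compound 2 to compound 3 (0.25 log units; within the scatter) when chloro gives way to methyl on an aromatic carbon, turning 2-chlorophenyl into 2-methylphenyl. For the compounds shown here, this is the first measured look at this position, as the earlier pair differed only in the hydroxy group on another part of the molecule, and it shows that compounds 2 and 3 cannot be told apart by this test, since their gap lies within the usual scatter of repeated measurements. Nothing available bears on why these two groups give numbers so close together.

With only chloro and methyl shown at this position, it remains open whether a group of a different kind, such as methoxy, trifluoromethyl or an amine, would move the number beyond the scatter. It is also open whether adding the hydroxy group, which gave a 3.6-fold lower number from compound 1 to compound 2 (0.55 log units; beyond the scatter) with 2-chlorophenyl in place, would have a similar effect with 2-methylphenyl in place, because the compound without hydroxy that carries 2-methylphenyl does not appear among those shown.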